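A few compounds are considered here, and "the series" means these few. Any claim that something is new, unique, unknown or untested is made for them only; others in the source may bear on it.

Working notes on the series. Compound 1 `O=C(Nc1cccc(-c2oc3cc(-c4ccc(F)cc4)ccc3c(=O)c2O)c1)c1ccc(Cl)cc1` gives 4030 nM in a functional assay on HCC1937 cells (Homo sapiens) for antiproliferative activity, read by CCK-8 assay, with a stated time of 72 h; a higher number here means a weaker inhibitor, a lower number a stronger inhibitor. For the measured compounds named here, compound 2 `O=C(Nc1cccc(-c2oc3cc(-c4ccc(F)cc4)ccc3c(=O)c2O)c1)c1ccc([N+](=O)[O-])cc1` gives 5640 nM in this assay; the step is a 1.4-fold higher number from compound 1 to compound 2 (0.15 log units; within the scatter), so compound 2 and compound 1 are not separated and compound 2 stands level with the only other measured compound.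

Compound 3 `CCCc1ccc(C(=O)Nc2cccc(-c3oc4cc(-c5ccc(F)cc5)ccc4c(=O)c3O)c2)cc1` is not yet measured. Its difference from compound 2 is propyl in place of nitro on an aromatic carbon, so the para substituent on the benzamide ring is again exchanged. The only measured step that bears on this position, a 1.4-fold higher number from compound 1 to compound 2 (0.15 log units; within the scatter), stayed within the scatter; no step covers propyl at this place, so the direction is not fixed by anything shown. The expectation for compound 3 is therefore a step of a 1.3-fold lower number from compound 2 to compound 3 (0.10 log units; within the scatter), no movement beyond the scatter, with the range kept wide for the untested group. The estimate for compound 3 in this assay is 4500 nM, between 1800 nM and 11000 nM.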

Compound 3, half-maximal inhibitory concentration: 15400 nM
Estimate against measurement, compound 3: 3.4-fold (0.53 log units) below; the whole stated range lies below it.
By their numbers in this assay, from the lowest: compounds 1 and 2 (each within the scatter of the next); then compound 3.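

In this assay the aromatic carbon para to a large group proves not to be indifferent to its substituent: propyl in place of nitro gives a 2.7-fold higher number from compound 2 to compound 3 (0.44 log units; beyond the scatter) and propyl in place of chloro gives a 3.8-fold higher number from compound 1 to compound 3 (0.58 log units; beyond the scatter) while the exchange of chloro for nitro, a 1.4-fold higher number from compound 1 to compound 2 (0.15 log units; within the scatter) stayed within the scatter. Chloro and nitro therefore remain level at this place, and propyl is the first group here to separate from them, in the direction of a weaker inhibitor. Nothing measured alongside these numbers accounts for the separation.

On these data alone, whether a shorter chain such as methyl or a longer chain such as butyl would stand nearer compound 3 or nearer compound 1 remains open. As far as these compounds go, how an amine or a carboxylic acid would stand at this carbon is equally open.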